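A few compounds are considered here, and "the series" means these few. Any claim that something is new, unique, unknown or untested is made for them only; others in the source may bear on it.

Measured in an assay for inhibition of beta-N-acetyl-D-hexosaminidase-A/B (Homo sapiens); a higher number here means a weaker inhibitor, a lower number a stronger inhibitor:
compound 1 `CCc1nc(N)ncc1-c1ccc(C(F)(F)F)cc1`: > 400000 nM, a limit of the assay and not a number
compound 2 `CCc1nc(N)nc(N)c1-c1cc(C)cc(C)c1`: 47000 nM
compound 3 `CCc1nc(N)nc(N)c1-c1ccc(C(F)(F)F)cc1`: 15000 nM

Compound 3 holds the lowest of the two numbers in this assay; compound 2 sits higher, beyond the scatter. Compound 1 reports only a limit (the limit of > 400000 nM in this assay, at which 1 of the 3 values shown sits). Going by the values given here, the single measured step, an at least 26-fold lower number from compound 1 to compound 3 (1.42 log units; beyond the scatter), concerns the amino group and does not touch the aryl substituent. Compound 4 `CCc1nc(N)nc(N)c1-c1ccc(C)cc1` carries methyl in place of trifluoromethyl on an aromatic carbon. Among the compounds with values here, no measured step covers this change; compounds 2 and 3, which differ in the aryl substitution, show the higher number for compound 2. Compound 4 is therefore expected to move toward compound 2, a modest rise estimated as a 2.0-fold higher number from compound 3 to compound 4 (0.30 log units; within the scatter). The value expected for compound 4 is 30000 nM, with a range from 10000 nM to 90000 nM.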

Compound 4, half-maximal inhibitory concentration: 40000 nM
Compound 4: the middle estimate sits 1.3-fold (0.12 log units) below what was measured, within the range that was stated.
By their numbers in this assay, from the lowest: compound 3; then compounds 4 and 2 (each within the scatter of the next). At a limit, above all of these: compound 1.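

Going by these compounds alone, replacing trifluoromethyl with methyl on the aromatic carbon para to a large group gives the first measured step at the aryl substituent: in this assay there is a 2.7-fold higher number from compound 3 to compound 4 (0.43 log units; beyond the scatter). This position therefore responds to the change, though less strongly than the amino position did in an at least 26-fold lower number from compound 1 to compound 3 (1.42 log units; beyond the scatter). No measured property available here accounts for the step.

Open, as far as these compounds go, is how chlorine, methoxy or a nitrile at this position would compare with trifluoromethyl and methyl. Also open, from the compounds shown here alone, is whether the amino step holds with methyl in place.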